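The source may report more compounds than this note shows. Statements on the series, on what has been measured and on what is new or still open speak of the compounds shown alone.

Measured compounds and their values:

Compound 1 `O=c1cc(Cn2cc(C3CC3)nn2)c2ccc(O)cc2o1`: in a functional assay on SW-620 cells (Homo sapiens) for inhibition, read by MTT assay, with a stated time of 72 h (on this read-out lower numbers stand for stronger inhibition and higher numbers for weaker inhibition), compound 1 gives > 100000 nM, which is a limit of the assay.
Compound 2 `CC(C)(C)c1cn(Cc2cc(=O)oc3cc(O)ccc23)nn1`: in this assay compound 2 gives > 100000 nM, again a limit of the assay.
Compound 3 `O=c1cc(Cn2cc(-c3ccc(Br)cc3)nn2)c2ccc(O)cc2o1`: in this assay compound 3 gives 97700 nM.

Compound 3 therefore stands as the only one of the three to give a number in this assay; the other two sit at the limit of > 100000 nM in this assay, at which 2 of the 3 values shown sit. The next compound is compound 4 `CCCC1CCC(c2ccc(-c3cn(Cc4cc(=O)oc5cc(O)ccc45)nn3)cc2)CC1`, which differs from compound 3 by 4-propylcyclohexyl in place of bromo on an aromatic carbon. Of the measured steps, an at least 1.0-fold lower number from compound 1 to compound 3 (0.01 log units; that floor lies within the scatter) and an at least 1.0-fold lower number from compound 2 to compound 3 (0.01 log units; that floor lies within the scatter) both end at compound 3 and exchange the group on the same aromatic carbon, but each is only a floor that lies within the scatter; a step that the two limits leave unreadable from compound 1 to compound 2 is left unreadable by the two limits. For the measured compounds named here, none of the measured steps alters a substituent on the 4-bromophenyl ring itself, so no step bears directly on the change to compound 4. On that basis a step of a 1.6-fold lower number from compound 3 to compound 4 (0.21 log units; within the scatter) is expected, which is not beyond the scatter. Compound 4 is thus estimated at 60000 nM in this assay, with a range from 15000 nM to 300000 nM.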

Compound 4, half-maximal inhibitory concentration: 37500 nM
Beside the measured number, compound 4's estimate is 1.6-fold (0.20 log units) above it, and the stated range covers the measured number.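

In this assay, the change at this aromatic carbon gives the first step of readable size among the compounds shown, a 2.6-fold lower number from compound 3 to compound 4 (0.42 log units; beyond the scatter). For the compounds shown here, until now, the only readable steps were floors within the scatter, and they exchanged the whole group on a different aromatic carbon, whereas this one shows that the carbon para to a large group on the six-membered aromatic ring accepts 4-propylcyclohexyl, with its 9 heavy atoms and one six-membered non-aromatic ring of carbon only, in place of the single bromine atom, with no rise in the number, though compound 4 still gives 37500 nM and the step is modest. Compound 1 and compound 2 remain limits of the assay rather than numbers, so they give no measured scale for this gain: the limit of > 100000 nM in this assay, at which 2 of the 4 values shown sit.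

The compounds shown leave open whether the step belongs to the non-aromatic ring or to the propyl chain on it, since a plain cyclohexyl or a longer chain on that ring does not appear among them. They also leave open how an amine or a carboxylic acid at this same aromatic carbon would read in this assay.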